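Swapping a Methyl for Hydrogen on an Aromatic Oxygen

A few compounds are considered here, and "the series" means these few. Any claim that something is new, unique, unknown or untested is made for them only; others in the source may bear on it.

Compound 2 `COc1ccc(/C=N/NC(=O)c2cnccn2)cc1OC` was examined in a functional assay on the whole organism (strain Swiss) for inhibition, with Mus musculus as the target, in the formalin test, with stated times of 40 min and 30 min, at a dose of 100 umol/kg by the oral route (on this read-out higher numbers stand for more inhibition at the one dose given (going by the name of the read-out) and lower numbers for less inhibition), where compound 2 gives 29.1%. Among the measured compounds shown here, that number stands second highest of the three measured so far, but the neighbours are close: compound 1 `COc1cc(/C=N/NC(=O)c2cnccn2)ccc1O` gives 31.8%, and compound 3 `O=C(N/N=C/c1ccc(C(F)(F)F)cc1)c1cnccn1` gives 27.7%, and all three lie within the scatter of one another, so no order among them can be read.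

The unmeasured compound 4 `COc1ccc(/C=N/NC(=O)c2cnccn2)cc1O` differs from compound 2 by hydrogen in place of methyl on an oxygen on an aromatic ring. A single measured step bears on this change, and it runs in the opposite direction: a number 2.7 percentage points lower from compound 1 to compound 2 (within the scatter). Because a number 2.7 percentage points lower from compound 1 to compound 2 (within the scatter) stayed within the scatter, the reverse exchange is expected to move the read-out no further, with any shift leaning slightly upward rather than downward.

Compound 4 is therefore estimated at 31%, within a range from 22% to 40%. The expected step is a number 1.9 percentage points higher from compound 2 to compound 4 (within the scatter), a change that lies within the scatter.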

Compound 4, a percentage reported as inhibition, in the whole organism at one dose (the size of the read-out at that dose, not a potency): 14.7%
Estimate against measurement, compound 4: 16.3 percentage points above; the measured number lies below the stated range.
By their numbers in this assay, from the lowest: compound 4; then compounds 3, 2 and 1 (each within the scatter of the next).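

The exchange of methoxy to hydroxy proves not to be silent at this oxygen: in this assay it gives a number 14.4 percentage points lower from compound 2 to compound 4 (beyond the scatter). The earlier step, which concerned the other oxygen of compound 2, gave a number 2.7 percentage points lower from compound 1 to compound 2 (within the scatter), so the two oxygens of compound 2 do not answer alike to the same exchange, and the methyl on the oxygen changed here matters to the read-out in a way the first three compounds gave no sign of. Nothing at hand explains this difference between the two oxygens.

The compounds shown leave open whether the methyl itself is what counts at this oxygen or whether an ethoxy group or a longer chain there would serve as well. They also leave open how an amine in place of the methoxy group would read in this assay.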